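The source may hold more compounds than are shown below. What is called first, only, known or untested is meant among the compounds shown, and "the series" means these compounds.

Three compounds share one core and differ only in the group on the far aromatic ring. Going by the values given here, compound 3 `O=C(/C=C/c1ccc2c(c1)B(O)OC2)c1ccc(OCc2ccccc2)cc1` carries a benzyloxy group there; in a toxicity assay on MCF-10A cells (Homo sapiens) for cytotoxicity, read by MTT assay, with a stated time of 48 h (a lower number here means a stronger inhibitor, a higher number a weaker inhibitor), compound 3 gives 23300 nM, the higher of the two plain numbers so far. Compound 1 `O=C(/C=C/c1ccc2c(c1)B(O)OC2)c1ccc(F)cc1` carries fluoro and gives 11800 nM. For compound 2 `O=C(/C=C/c1ccc2c(c1)B(O)OC2)c1ccc(I)cc1`, the iodo analogue, the result is a limit of the assay: > 100000 nM (the limit of > 100000 nM in this assay, at which 1 of the 3 values shown sits). Among the compounds with values here, the change a 2.0-fold higher number from compound 1 to compound 3 (0.30 log units; within the scatter) stays within the scatter, so compound 3 and compound 1 cannot be ranked against each other, while an at least 4.2-fold lower number from compound 2 to compound 3 (0.63 log units; beyond the scatter) is the one clear step.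

Compound 4 `Nc1ccc(C(=O)/C=C/c2ccc3c(c2)B(O)OC3)cc1` is the next member: amino in place of benzyloxy on an aromatic carbon. Both measured steps touch this same position, and only the iodo case moved the number beyond the scatter. Swapping benzyloxy for the small amino group is therefore expected to leave a 1.6-fold lower number from compound 3 to compound 4 (0.19 log units; within the scatter), that is, no shift beyond the scatter. Compound 4 is expected at about 15000 nM, within 5000 nM to 50000 nM.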

Compound 4, half-maximal inhibitory concentration: 19900 nM
Estimate against measurement, compound 4: 1.3-fold (0.12 log units) below, and the stated range covers the measured number.
By their numbers in this assay, from the lowest: compounds 1, 4 and 3 (each within the scatter of the next). At a limit, above all of these: compound 2.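

Amino is a far smaller group than benzyloxy, with 1 heavy atom against 8, no ring and a hydrogen-bond donor, yet in this assay the exchange gives a 1.2-fold lower number from compound 3 to compound 4 (0.07 log units; within the scatter). The comparison with fluoro gives a 1.7-fold higher number from compound 1 to compound 4 (0.23 log units; within the scatter), so compounds 1, 3 and 4 cannot be ranked against each other, even though their groups at this position differ widely. Compound 2 is the one exception, as an at least 5.0-fold lower number from compound 2 to compound 4 (0.70 log units; beyond the scatter) shows, and its value is a limit of the assay rather than a number: the limit of > 100000 nM in this assay, at which 1 of the 4 values shown sits.

As far as these compounds go, it remains open whether a carboxylic acid or a longer alkyl chain at this position would stay level with compounds 1, 3 and 4. Chloro and bromo would show whether the separation of compound 2 extends to other halogens or belongs to iodo alone.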